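This account rests on a few compounds, and the source may have more. Where it says the series, first, only, none or still open, it means among the compounds named here.

Three compounds that share a pyrimidinone-bearing arrangement were measured in an assay on HEK293T cells for inhibition, read by scintillation counting, with stated times of 5 min and 15 min, at pH 5.5; on this read-out lower numbers stand for stronger inhibition and higher numbers for weaker inhibition. Compound 1, `Cc1cc(=O)[nH]c(-n2nc(C)c(C)c2C)n1`, gives 10000 nM in this assay. Compound 2, `CCc1c(C)nn(-c2nc(C)cc(=O)[nH]2)c1C`, differs from compound 1 only by methyl in place of hydrogen on a saturated chain carbon bound to an aromatic carbon, and in this assay compound 2 gives 4200 nM. That single change produced a 2.4-fold lower number from compound 1 to compound 2 (0.38 log units; beyond the scatter). Compound 3, `Cc1cc(=O)[nH]c(-n2nc3c(c2C)CCCC3)n1`, is built on a different core, and the difference between the two cores is not broken down here. In this assay compound 3 gives 1100 nM, the lowest of the three numbers, and its gaps to compound 2 and to compound 1 both lie beyond the scatter.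

Compound 4, `CCc1c2c(nn1-c1nc(C)cc(=O)[nH]1)CCCC2`, has not yet been measured. It differs from compound 3 by methyl in place of hydrogen on a saturated chain carbon bound to an aromatic carbon, the same change that separates compound 2 from compound 1, at the same place. Because that change gave a 2.4-fold lower number from compound 1 to compound 2 (0.38 log units; beyond the scatter) on the core of compound 1, a step of about the same size is expected on the core of compound 3. This expectation rests on one earlier instance only, on a different core, so the true step may be larger or smaller. For compound 4 the expected step is a 2.4-fold lower number from compound 3 to compound 4 (0.38 log units; beyond the scatter). The number for compound 4 is expected to fall between 200 nM and 1500 nM. The estimate for compound 4 in this assay is 460 nM.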

Compound 4, half-maximal inhibitory concentration: 2260 nM
The estimate for compound 4 lay 4.9-fold (0.69 log units) below the measured number; the measured number lies above the stated range.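

In this assay, placing a methyl in place of hydrogen on a saturated chain carbon bound to an aromatic carbon, which turns methyl to ethyl, gives a 2.1-fold higher number from compound 3 to compound 4 (0.31 log units; beyond the scatter), so on this core the number rises instead of falling. In this series, therefore, the change does not carry from one core to another with the same direction, and the result on one core could not be used as a reliable guide to the result on the other: the same change on two cores in this assay, a 2.4-fold lower number (0.38 log units; beyond the scatter) from compound 1 to compound 2 and a 2.1-fold higher number (0.31 log units; beyond the scatter) from compound 3 to compound 4, 4.9-fold (0.69 log units) apart, beyond the scatter of two such steps. For the compounds shown here, this does not show which feature of the cores sets the two results apart, nor how a further core would respond, since each core contributes only a single pair of compounds.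

At this place, the compounds shown carry only methyl and ethyl, so it remains open how a propyl chain, an amine or a carboxylic acid would move the number on either core. As far as these compounds go, it also remains open whether a further core would follow the step from compound 1 to compound 2, the step from compound 3 to compound 4, or neither.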